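Swapping Hydroxymethyl for Hydroxy on an Anilide Biphenyl

A few compounds are considered here, and "the series" means these few. Any claim that something is new, unique, unknown or untested is made for them only; others in the source may bear on it.

Compound 1 `CC(=O)Nc1cccc(-c2ccc(CO)cc2)c1`: < 10%
Compound 2 `O=C(Nc1cccc(-c2ccc(CO)cc2)c1)c1ccccc1`: < 10%
Compound 3 `CN(C(=O)c1ccccc1)c1cccc(-c2ccc(CO)cc2)c1`: < 10%

In an assay for binding affinity to 17-beta-hydroxysteroid dehydrogenase type 1 (Homo sapiens), with a stated time of 20 min, tested at 1 uM (a higher number here means more inhibition at the concentration tested (going by the name of the read-out), a lower number less inhibition), compound 1 gives < 10%, which is a limit of the assay and not a number. Compound 2 likewise returns only a limit, < 10%. Compound 3 also sits at a limit, < 10%. The step that the two limits leave unreadable from compound 1 to compound 2 and the step that the two limits leave unreadable from compound 2 to compound 3 therefore have no readable size, because of the limit of < 10% in this assay, at which 3 of the 3 values shown sit. Compound 2 thus stands at the floor of this assay, with nothing to rank it against compounds 1 and 3. Compound 4 `O=C(Nc1cccc(-c2ccc(O)cc2)c1)c1ccccc1` differs from compound 2 by hydroxy in place of hydroxymethyl on an aromatic carbon. Going by the values given here, no measured step bears on this change, so no size can be carried over; any rise in this assay is expected to be modest and uncertain. For compound 4 an inhibition of 30% is expected, between 5% and 65%. That expectation corresponds to a step of a number at least 20 percentage points higher from compound 2 to compound 4 (beyond the scatter).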

Compound 4, a percentage reported as inhibition, at one concentration (the size of the read-out at that concentration, not a potency): < 10%
Compound 4 was reported as a limit; the forecaster's own chance of this, stated with the estimate: 40%; middle value at least 20 percentage points away from the limit.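

Compound 4 gives < 10%, again a limit and not a number, so no size can be read for the change from compound 2 to compound 4: the limit of < 10% in this assay, at which 4 of the 4 values shown sit. The compounds shown leave open which change to the shared core, if any, would lift the read-out off this limit in this assay.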